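A few compounds are considered here, and "the series" means these few. Any claim that something is new, unique, unknown or untested is made for them only; others in the source may bear on it.

In a functional assay on SH-SY5Y cells (Homo sapiens) for cytotoxicity, read by MTT assay, with a stated time of 72 h (a lower number here means a stronger inhibitor, a higher number a weaker inhibitor), compound 1 `O=C1c2c[n+]([O-])c3ccccc3c2C(=O)c2c1c1ccccc1n2Cc1cn(C[C@H](O)CO)nn1` gives > 1000 nM, which is a limit of the assay and not a number. Compound 2 `CN1CCN(CCCCn2c3c(c4ccccc42)C(=O)c2c[n+]([O-])c4ccccc4c2C3=O)CC1` gives an actual number, 100 nM. For the measured compounds named here, the one measured step is an at least 10-fold lower number from compound 1 to compound 2 (1.00 log units; beyond the scatter), and it replaces the whole 1-(2,3-dihydroxypropyl)-1H-1,2,3-triazol-4-yl group with 3-(4-methylpiperazin-1-yl)propyl.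

Compound 3 `O=C1c2c[n+]([O-])c3ccccc3c2C(=O)c2c1c1ccccc1n2Cc1cn([C@H]2C[C@H](O)[C@@H](CO)O2)nn1` differs from compound 1 in a smaller way: 4-hydroxy-5-(hydroxymethyl)oxolan-2-yl in place of 2,3-dihydroxypropyl on an aromatic nitrogen. Here 4-hydroxy-5-(hydroxymethyl)oxolan-2-yl takes the place of 2,3-dihydroxypropyl on an aromatic nitrogen of the five-membered aromatic ring with 3 nitrogen, and that ring stays. The step of an at least 10-fold lower number from compound 1 to compound 2 (1.00 log units; beyond the scatter) brought in a 3-(4-methylpiperazin-1-yl)propyl group, which compound 3 does not carry, so that large drop is not expected to repeat. Going by the values given here, no measured step covers this swap directly, and the starting point is only a limit, so no step beyond the scatter is expected in this assay. The estimated change is a step that the limit leaves unreadable from compound 1 to compound 3. For compound 3 the expected value is 2000 nM, with an estimated range from 700 nM to 8000 nM.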

Compound 3, half-maximal inhibitory concentration: 620 nM
Estimate against measurement, compound 3: 3.2-fold (0.51 log units) above; the measured number lies below the stated range.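

In this assay compound 3 gives a real number, 620 nM, so changing only the group on the aromatic nitrogen, with the five-membered aromatic ring with 3 nitrogen kept in place, brings the value within the range the assay can read, and this happens without the 3-(4-methylpiperazin-1-yl)propyl group. The change is read as an at least 1.6-fold lower number from compound 1 to compound 3 (0.20 log units; that floor lies within the scatter), so what is known is only a floor, and that floor alone does not establish a real difference between the 2,3-dihydroxypropyl and 4-hydroxy-5-(hydroxymethyl)oxolan-2-yl groups. Compound 1 stands at a limit and not at a number, so the true size of the step cannot be read: the limit of > 1000 nM in this assay, at which 1 of the 3 values shown sits.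

The compounds shown do not separate the contribution of the oxolane ring from that of its defined stereocentres, since the two change together in this single swap. Also open, from the compounds shown here alone, is what a smaller group on the same aromatic nitrogen would give, such as a plain 2-hydroxyethyl chain, or a group carrying a dimethylamino amine or a carboxylic acid.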